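The source may hold more compounds than are shown below. What is called first, only, known or untested is meant among the compounds shown, and "the series" means these compounds.

Measured compounds in this set:
- compound 1 `OCc1cn(Cc2ccccc2)c2ccccc12`: 112 nM
- compound 2 `OCc1cn(Cc2ccccc2Cl)c2ccccc12`: 100 nM
- compound 3 `OCc1cn(Cc2ccc(Cl)cc2)c2ccccc12`: 16 nM

In a functional assay on NCI-H460 cells (Homo sapiens) for cytotoxicity, read by sulforhodamine B assay, with a stated time of 3 days (on this read-out lower numbers stand for stronger inhibition and higher numbers for weaker inhibition), compound 1 gives the highest number of the three. Compound 2 sits within the scatter of it, as shown by a 1.1-fold lower number from compound 1 to compound 2 (0.05 log units; within the scatter). Compound 3 stands furthest from it, as shown by a 7.0-fold lower number from compound 1 to compound 3 (0.85 log units; beyond the scatter), a modest step beyond the scatter.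

Compound 4 `OCc1cn(Cc2cccc(Br)c2)c2ccccc12` has not yet been measured in this assay. It differs from compound 1 by bromo in place of hydrogen on an aromatic carbon. Both measured steps bear on this change, since each of them also puts a halogen in place of a hydrogen on the same six-membered ring of compound 1; neither, however, uses bromo, and neither sits on the carbon used in compound 4. The two steps disagree: one stays within the scatter, the other is a modest drop in the number. With no closer guide, a step lying between these two outcomes is expected, leaning toward a lower number, a 2.5-fold lower number from compound 1 to compound 4 (0.40 log units; beyond the scatter). For compound 4 a value of 45 nM is estimated, with a range from 15 nM to 140 nM.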

Compound 4, half-maximal inhibitory concentration: 28 nM
Compound 4: the middle estimate sits 1.6-fold (0.21 log units) above what was measured; low and high end bracket the measured number.
By their numbers in this assay, from the lowest: compounds 3 and 4 (each within the scatter of the next); then compounds 2 and 1 (each within the scatter of the next).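

In this assay bromo in place of hydrogen on an aromatic carbon, meta to a large group, gives a step beyond the scatter (a 4.0-fold lower number from compound 1 to compound 4 (0.60 log units; beyond the scatter)). This adds a third position on the six-membered aromatic ring of compound 1 to the series and shows that a halogen on this carbon moves the number, as chloro does in compound 3 but not in compound 2 (a 1.1-fold lower number from compound 1 to compound 2 (0.05 log units; within the scatter)), so a halogen on this ring does not act alike at every carbon. No measured information is available to explain this step.

The compounds shown do not separate the contribution of bromo from that of the carbon it occupies, since each of the three halogen steps from compound 1 uses a different carbon, and chloro on the carbon used in compound 4 would be the direct comparison. From the compounds shown here alone, it also remains open whether a group other than a halogen on this carbon, such as a methoxy group or an amine, would give a step of similar size.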